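Series notes: thiophene for furan on the saturated ring carbon

A few compounds are considered here, and "the series" means these few. Any claim that something is new, unique, unknown or untested is made for them only; others in the source may bear on it.

Measured so far:
compound 1 `CCSC(=O)C1=C(C)NC(=O)NC1c1ccsc1`: 11%
compound 2 `CC1=C(C(=O)OC2CCC2)C(c2ccco2)NC(=O)N1`: 19%

In an assay on membranes from CHO cells for displacement of a labelled ligand from adenosine receptor A1 (Homo sapiens), read by scintillation counting, with a stated time of 60 min, tested at 1 uM (on this read-out higher numbers stand for more inhibition at the one concentration tested (going by the name of the read-out) and lower numbers for less inhibition), compound 2 gives 19%. Among the compounds with values here, the only other number in hand comes from compound 1, which gives 11% in this assay; the gap between the two is within the scatter, so neither number can be called the higher, and no step between measured compounds isolates any single change.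

Compound 3 `CC1=C(C(=O)OC2CCC2)C(c2ccsc2)NC(=O)N1` differs from compound 2 in one place: thiophen-3-yl in place of furan-2-yl on a saturated ring carbon. Compound 1 also carries thiophen-3-yl, and its number in this assay lies within the scatter of compound 2, which gives no hint of a shift in either direction. The step from compound 2 to compound 3 in this assay is therefore expected to be none beyond the scatter, that is a number 4 percentage points lower from compound 2 to compound 3 (within the scatter). Compound 3 is estimated to give 15% in this assay, within a range of 3% to 30%.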

Compound 3, a percentage reported as inhibition, at one concentration (the size of the read-out at that concentration, not a potency): 40%
For compound 3 the middle estimate is 25 percentage points below the measured one; measured number outside the range, above it.
By their numbers in this assay, from the lowest: compounds 1 and 2 (each within the scatter of the next); then compound 3.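

In this assay the saturated ring carbon of the shared core proves sensitive to which five-membered aromatic ring it carries: thiophen-3-yl in place of furan-2-yl gives a number 21 percentage points higher from compound 2 to compound 3 (beyond the scatter) with cyclobutyloxy held on the carbonyl carbon. The carbonyl carbon is sensitive too, since cyclobutyloxy in place of ethylsulfanyl gives a number 29 percentage points higher from compound 1 to compound 3 (beyond the scatter) with thiophen-3-yl held on the ring. Nothing in hand accounts for either step.

Open, going by these compounds, is whether thiophen-2-yl or phenyl on the saturated ring carbon would behave like thiophen-3-yl, and whether the ring step would persist with ethylsulfanyl on the carbonyl carbon. Also open, on these data alone, is how an amine or a longer alkoxy chain in place of cyclobutyloxy would read in this assay on the same core.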